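The source may report more compounds than this note shows. Statements on the series, on what has been measured and on what is new or still open speak of the compounds shown alone.

Of the compounds shown here, three have been measured in a functional assay on thoracic aorta (Rattus norvegicus, strain Wistar), with a stated time of 15 min; on this read-out higher numbers stand for an effect only at larger amounts of compound and lower numbers for an effect already at smaller amounts. Compound 1 `CCOc1ccc(F)cc1C(C)NC(=O)NS(=O)(=O)c1ccc(Cl)cc1` reaches only the limit of the assay, > 300000 nM. Compound 2 `CCOc1ccc(F)cc1C(C)NC(=O)N(C)S(=O)(=O)c1ccc(Cl)cc1` gives 24500 nM in this assay. Compound 3 `Cc1ccc(OCc2ccccc2)c(C(C)NC(=O)N(C)S(=O)(=O)c2ccccc2)c1` gives 68200 nM in this assay; how its core differs from the core of compound 2 is not broken down here. Compound 2 and compound 1 differ in a single place: hydrogen in place of methyl on an amide-type nitrogen This change brought an at least 12-fold higher number from compound 2 to compound 1 (1.08 log units; beyond the scatter). The value of compound 1 there is the limit of > 300000 nM in this assay, at which 1 of the 3 values shown sits. Compound 4 `Cc1ccc(OCc2ccccc2)c(C(C)NC(=O)NS(=O)(=O)c2ccccc2)c1` is not yet measured. It differs from compound 3 by the same change at the same place: hydrogen in place of methyl on an amide-type nitrogen Because the earlier change gave an at least 12-fold higher number from compound 2 to compound 1 (1.08 log units; beyond the scatter), a step of similar size is expected here, an 8.8-fold higher number from compound 3 to compound 4 (0.94 log units; beyond the scatter). Compound 4 is therefore estimated at 600000 nM, with a real chance that only a limit is reported.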

Compound 4, half-maximal effective concentration: > 200000 nM
Compound 4: a limit, no number; the forecaster's own chance of this, stated with the estimate: 75%; the middle value is on the limit's open side.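

In this assay, hydrogen in place of methyl on the amide-type nitrogen brings an at least 2.9-fold higher number from compound 3 to compound 4 (0.46 log units; beyond the scatter), so the direction of the change holds on both cores shown. On these data alone, compound 4 gives only a limit of the assay, > 200000 nM, so the full size of this step is unknown. The comparison therefore shows a shared direction but no shared size: the same change on two cores in this assay, an at least 12-fold higher number (1.08 log units; beyond the scatter) from compound 2 to compound 1 and an at least 2.9-fold higher number (0.46 log units; beyond the scatter) from compound 3 to compound 4; the limit leaves it open whether they differ

The compounds shown leave open how an ethyl group or a longer chain on that nitrogen would compare with methyl. Within the data shown here, with only two cores here, they also leave open whether the same direction would hold on a core carrying an amine or a carboxylic acid.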